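The compounds below may be only part of what the source reports. "The series", "measured", "known", "first", "only" and "open" are said of these compounds alone.

Numbers in an assay on isolated protein for inhibition of tyrosine-protein kinase Mer (Homo sapiens), read by LC-MS (a lower number here means a stronger inhibitor, a higher number a weaker inhibitor), for the three measured compounds:

compound 1 `CN(Cc1ccc2nccn2c1)c1nnc(-c2ccccc2)o1`: 15800 nM
compound 2 `CN(Cc1ccc2nccn2c1)c1nnc(-c2ccc(-c3ccccc3C#N)cc2)o1`: 25.1 nM
compound 3 `Cc1nn(C)c(C)c1-c1ccc(-c2nnc(N(C)Cc3ccc4nccn4c3)o2)cc1`: 31.6 nM

Compound 3 holds the second highest of the three numbers. Its nearest neighbour is compound 2, a gap that is within the scatter (a 1.3-fold higher number from compound 2 to compound 3 (0.10 log units; within the scatter)), so nothing separates the two; compound 1 lies far away, the step of a 500-fold lower number from compound 1 to compound 3 (2.70 log units; beyond the scatter) being beyond the scatter.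

Compound 4 `Cc1nn(C)c(C)c1-c1ccc(-c2nnc(N(C)Cc3ccc4nccn4c3)o2)c(C#N)c1` is not yet measured. Relative to compound 3 the change is cyano in place of hydrogen on an aromatic carbon; the new group sits ortho to a large group and meta to the 1,3,5-trimethyl-1H-pyrazol-4-yl group, on the shared core.

Within the data shown here, no measured step isolates this change. The two large steps, a 630-fold lower number from compound 1 to compound 2 (2.80 log units; beyond the scatter) and a 500-fold lower number from compound 1 to compound 3 (2.70 log units; beyond the scatter), both concern a whole aryl or heteroaryl group entering in place of hydrogen, a different kind of change. Compound 2 does carry a cyano group within its 2-cyanophenyl, and its number and that of compound 3 are within scatter of each other, which gives no indication either way. A step no larger than the scatter is therefore expected for a 1.1-fold lower number from compound 3 to compound 4 (0.05 log units; within the scatter), with no clear direction.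

The estimate for compound 4 in this assay is 28 nM, with a range from 9 nM to 90 nM.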

Compound 4, half-maximal inhibitory concentration: 100000 nM
Compound 4: middle estimate off by 3600-fold (3.55 log units), on the low side; measured number outside the range, above it.
By their numbers in this assay, from the lowest: compounds 2 and 3 (each within the scatter of the next); then compound 1; then compound 4.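

In this assay, a 3200-fold higher number from compound 3 to compound 4 (3.50 log units; beyond the scatter), so a cyano group in place of hydrogen on this aromatic carbon, ortho to a large group and meta to the 1,3,5-trimethyl-1H-pyrazol-4-yl group, is far from a neutral change. All three earlier compounds carry hydrogen at this place, so they showed only what the aryl and heteroaryl groups contribute, and compound 4 shows that the gain seen in a 500-fold lower number from compound 1 to compound 3 (2.70 log units; beyond the scatter) does not survive this single added group even though the 1,3,5-trimethyl-1H-pyrazol-4-yl group is still present. No measurement shown here accounts for the size of this step, and the compounds offer no explanation of it.

The compounds shown leave open whether this place rejects substitution in general or the cyano group in particular, which a fluorine atom, a methyl group or a methoxy group at the same carbon would begin to separate. Also open, as far as these compounds go, is whether the same cyano group has a comparable effect when the 2-cyanophenyl group of compound 2 stands in place of the 1,3,5-trimethyl-1H-pyrazol-4-yl group.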